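Replacing the five-membered ring on sulfur in compound 1

The compounds below may be only part of what the source reports. "The series", "measured", "known", "first", "only" and "open" are said of these compounds alone.

Compound 1 `Cc1ccc(-c2cs/c(=N/NC(=O)CSc3nncn3C)n2-c2ccccc2)cc1` was tested in a functional assay on C6 cells (Rattus norvegicus) for cytotoxicity, read by MTT assay, with a stated time of 24 h, tested at 6 ug/mL (a higher number here means a weaker effect of the compound at the concentration tested, a lower number a stronger effect), where compound 1 gives 74.6%. Two close relatives were measured alongside it. Compound 2 `Cn1cnnc1SCC(=O)N/N=c1/scc(-c2ccc(C#N)cc2)n1-c1ccccc1` gives 70.2%, and compound 3 `Cn1cnnc1SCC(=O)N/N=c1/scc(-c2ccccc2)n1-c1ccccc1` gives 90%. Among these three numbers compound 1 stands second highest: the step of a number 4.4 percentage points lower from compound 1 to compound 2 (within the scatter) is within the scatter, whereas the step of a number 15.4 percentage points higher from compound 1 to compound 3 (beyond the scatter) is beyond it, as is a number 19.8 percentage points higher from compound 2 to compound 3 (beyond the scatter). All three measured steps concern the group on an aromatic carbon at one end of the shared core, and they are modest.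

Compound 4 `Cc1ccc(-c2cs/c(=N/NC(=O)CSc3ncccn3)n2-c2ccccc2)cc1` changes a different part of compound 1: pyrimidin-2-yl in place of 4-methyl-4H-1,2,4-triazol-3-yl on a sulfur. Among the compounds with values here, no measured step touches this sulfur-bound group, so nothing in the data shows how the read-out in this assay responds to it. Within the data shown here, the only guide is the general picture: every change tried so far moved the number by modest amounts at most. The expectation is therefore a value near that of compound 1, with no step beyond the scatter, in either direction. Compound 4 is expected to give 77%, within a range from 60% to 94%. For compound 4 this amounts to an expected step of a number 2.4 percentage points higher from compound 1 to compound 4 (within the scatter).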

Compound 4, a percentage reported as activity, at one concentration (the size of the read-out at that concentration, not a potency): 93.2%
Estimate against measurement, compound 4: 16.2 percentage points below; the range from low to high includes it.
By their numbers in this assay, from the lowest: compounds 2 and 1 (each within the scatter of the next); then compounds 3 and 4 (each within the scatter of the next).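

In this assay, pyrimidin-2-yl in place of 4-methyl-4H-1,2,4-triazol-3-yl on the sulfur gives a number 18.6 percentage points higher from compound 1 to compound 4 (beyond the scatter), so the effect of the compound at the tested concentration is weaker after this change. Within the data shown here, this shows that the group on the sulfur also influences the read-out, which the earlier steps could not show, since they changed only a group on an aromatic carbon at the other end of the molecule. The two groups have the same number of heavy atoms and neither carries a net charge, yet they differ in ring size, in the number of ring nitrogens and in the presence of the methyl group, and no measurement here explains why the number moves or separates these differences.

A pyridin-2-yl group or a plain methyl group on this sulfur would help to show which of these differences matters. On these data alone, it also remains open whether the same exchange would shift the number similarly with the cyano group of compound 2, or with the hydrogen of compound 3, at the other end of the molecule.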